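Methoxy in Place of Fluoro: A Small Step Expected

The compounds below may be only part of what the source reports. "The series", "measured", "known", "first", "only" and "open" are said of these compounds alone.

Among the compounds with values here, compound 2 `C=CC(=O)Nc1cccc(NC(=O)CSc2nc(Nc3cccc(F)c3)c3ccccc3n2)c1` is one of two compounds measured in a functional assay on MDA-MB-231 cells (Homo sapiens) for inhibition, read by MTT assay, with a stated time of 72 h; a higher number here means a weaker inhibitor, a lower number a stronger inhibitor: compound 2 gives 8160 nM, while compound 1 `C=CC(=O)Nc1cccc(NC(=O)CSc2nc(Nc3ccccc3)c3ccccc3n2)c1` gives 10200 nM, and the two stand within the scatter of each other, as the step of a 1.3-fold lower number from compound 1 to compound 2 (0.10 log units; within the scatter) shows. Compound 3 `C=CC(=O)Nc1cccc(NC(=O)CSc2nc(Nc3cccc(OC)c3)c3ccccc3n2)c1` differs from compound 2 by methoxy in place of fluoro on an aromatic carbon. Within the data shown here, the only measured step swapped hydrogen for fluoro, not fluoro for methoxy, and stayed within the scatter, so it bears only loosely here. No step beyond the scatter is expected in this assay. Compound 3 is estimated at 8000 nM, between 3000 nM and 22000 nM, which means an expected 1.0-fold lower number from compound 2 to compound 3 (0.01 log units; within the scatter).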

Compound 3, half-maximal inhibitory concentration: 12900 nM
Estimate against measurement, compound 3: 1.6-fold (0.21 log units) below, within the range that was stated.
By their numbers in this assay, from the lowest: compounds 2, 1 and 3 (each within the scatter of the next).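

In this assay, methoxy in place of fluoro gives (a 1.6-fold higher number from compound 2 to compound 3 (0.20 log units; within the scatter)) and methoxy in place of hydrogen gives (a 1.3-fold higher number from compound 1 to compound 3 (0.10 log units; within the scatter)). At this place, on the six-membered aromatic ring of carbon only and meta to a large group, the assay therefore separates none of hydrogen, fluoro and methoxy, even though methoxy is larger than fluoro and adds a hydrogen-bond acceptor. No measured evidence bears on why these three compounds read alike. From the compounds shown here alone, whether an amine or a carboxylic acid at this place would move the number beyond the scatter stays open. So does the reading for a longer chain, such as butoxy.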